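Hydroxyacyl side chains on a shared thienyl carboxamide core

A few compounds are considered here, and "the series" means these few. Any claim that something is new, unique, unknown or untested is made for them only; others in the source may bear on it.

Compound 2 `CC1(C)Cc2c(sc(NC(=O)[C@H](O)C(C)(C)C)c2C(N)=O)C(C)(C)O1` carries a 1-hydroxy-2,2-dimethylpropyl group on the carbonyl carbon of the amide. Within the data shown here, in an assay on cells for positive allosteric modulation of Cystic fibrosis transmembrane conductance regulator variant G551D (Homo sapiens), with stated times of 10 min and 2 min, in the presence of a further agent that is not named here (a lower number here means that less compound is needed, a higher number that more compound is needed for the effect), compound 2 gives 7780 nM, the highest of the two numbers so far; its nearest neighbour is compound 1 `CC1(C)Cc2c(sc(NC(=O)C3(CO)CC3)c2C(N)=O)C(C)(C)O1`, which in this assay gives 1320 nM. Among the measured compounds shown here, the one measured step is a 5.9-fold higher number from compound 1 to compound 2 (0.77 log units; beyond the scatter), a ring-bearing hydroxymethyl group giving way to an open hydroxyalkyl chain.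

Compound 3 `CC(C)(C)CC(O)C(=O)Nc1sc2c(c1C(N)=O)CC(C)(C)OC2(C)C` differs from compound 2 by a group of 7 heavy atoms (6 carbon, 1 oxygen; no ring) in place of a group of 6 heavy atoms (5 carbon, 1 oxygen; no ring), on a carbonyl carbon: the chain between the hydroxy-bearing carbon and the terminal branching grows by one carbon, and the defined stereocentre is no longer specified. For the measured compounds named here, no measured step covers a one-carbon lengthening of this chain; the only step in hand, a 5.9-fold higher number from compound 1 to compound 2 (0.77 log units; beyond the scatter), exchanged the whole group and is at best a rough guide. An open chain of this kind is not expected to move far from compound 2, and the step of a 1.3-fold lower number from compound 2 to compound 3 (0.11 log units; within the scatter) is estimated to stay small. For compound 3 the estimate in this assay is 6000 nM, with a range of 2000 nM to 18000 nM.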

Compound 3, half-maximal effective concentration: 981 nM
Compound 3: middle estimate off by 6.1-fold (0.79 log units), on the high side; measured number outside the range, below it.
By their numbers in this assay, from the lowest: compounds 3 and 1 (each within the scatter of the next); then compound 2.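

Working notes on the position: on this carbonyl carbon, the open-chain group of 7 heavy atoms in place of 1-hydroxy-2,2-dimethylpropyl gives a 7.9-fold lower number from compound 2 to compound 3 (0.90 log units; beyond the scatter) in this assay, so two open hydroxyalkyl groups of close size are not interchangeable here. The further step, a 1.3-fold lower number from compound 1 to compound 3 (0.13 log units; within the scatter), shows that the three-membered ring of 1-(hydroxymethyl)cyclopropyl is not required for a number in this range, although compound 2 shows that an open chain does not by itself guarantee one. No measurement in hand gives a reason for either step.

The step from compound 2 to compound 3 combines the change in the group with the loss of the defined stereocentre, so the compounds shown leave open how much of it belongs to each change, and the separate stereoisomers of compound 3 would be needed to divide the two. Also open, on these data alone, is whether the trend continues with a longer chain, and whether the hydroxy group can give way to an amine or a carboxylic acid on this carbonyl carbon.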